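A few compounds are considered here, and "the series" means these few. Any claim that something is new, unique, unknown or untested is made for them only; others in the source may bear on it.

The measured compounds:

Compound 1, `O=C(O)CCCC1=CC[C@@H]2[C@@H](/C=C/[C@@H](O)COc3ccccc3)[C@H](O)C[C@@H]2OC1`, in an ADME assay on CHO cells for agonist activity at prostacyclin receptor (Homo sapiens), read by HTRF and cAMP accumulation (a lower number here means that less compound is needed, a higher number that more compound is needed for the effect), gives > 10000 nM, which is a limit of the assay rather than a number.
Compound 2, `O=C(O)CCCCC1=CC[C@@H]2[C@@H](/C=C/[C@@H](O)COc3ccccc3)[C@H](O)C[C@@H]2OC1`, in this assay gives > 10000 nM, again only a limit.
Compound 3, `O=C(O)CC[C@@H]1CC[C@@H]2[C@@H](/C=C/[C@@H](O)COc3ccccc3)[C@H](O)C[C@@H]2OC1`, in this assay gives > 10000 nM, also a limit.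

Compound 1 and compound 2 differ by carboxymethyl in place of carboxy on a saturated chain carbon, three bonds along the chain from a double-bonded ring carbon. The step in this assay is a step that the two limits leave unreadable from compound 1 to compound 2, and it cannot be read because of the limit of > 10000 nM in this assay, at which 3 of the 3 values shown sit.

Compound 4, `O=C(O)CCC[C@@H]1CC[C@@H]2[C@@H](/C=C/[C@@H](O)COc3ccccc3)[C@H](O)C[C@@H]2OC1`, has not yet been measured in this assay. It differs from compound 3 by carboxymethyl in place of carboxy on a saturated chain carbon, two bonds along the chain from a saturated ring carbon. This is the same kind of change as that from compound 1 to compound 2, but the place is not the same: in compound 1 the chain carbon sits three bonds along the chain from a double-bonded ring carbon, whereas in compound 3 it sits two bonds along the chain from a saturated ring carbon. The difference between the core of compound 1 and the core of compound 3 is not broken down here.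

With all three measured values sitting at the limit, the only indication is that the earlier step of the same kind left compound 2 at the limit as well. The estimated step from compound 3 to compound 4 is therefore a step that the limit leaves unreadable from compound 3 to compound 4. Compound 4 is expected to give 15000 nM in this assay, most likely again reported as a limit, with an estimated range from 3000 nM to 50000 nM.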

Compound 4, half-maximal effective concentration: > 10000 nM
Compound 4 ended at the assay's limit (the forecaster's own chance of this, stated with the estimate: 80%); the middle value lies beyond the limit too.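

The step from compound 3 to compound 4 cannot be read, and neither can any other step among the four compounds, because compound 3 and compound 4 sit at the same limit as compound 1 and compound 2: the limit of > 10000 nM in this assay, at which 4 of the 4 values shown sit.

The compounds shown leave open how far each lies beyond that limit, and so whether going from 2-carboxyethyl to 3-carboxypropyl changes anything in this assay.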